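The compounds below may be only part of what the source reports. "The series", "measured", "known", "first", "only" and "open" are said of these compounds alone.

Among the compounds with values here, compound 2 `Cc1nnc(SCC(=O)[C@H](CC(=O)O)NC(=O)[C@@H](NC(=O)COc2cccc3ccccc23)C(C)C)s1` is the only compound here with a number in a functional assay on Jurkat cells (Homo sapiens) for inhibition; a higher number here means a weaker inhibitor, a lower number a stronger inhibitor: compound 2 gives 190000 nM. Compound 1 `CC(C)c1cc(OCC(=O)[C@H](CC(=O)O)NC(=O)[C@@H](NC(=O)COc2cccc3ccccc23)C(C)C)no1` gives only a limit of the assay in this assay, > 200000 nM. Within the data shown here, the single measured step, an at least 1.0-fold lower number from compound 1 to compound 2 (0.02 log units; that floor lies within the scatter), lies within the scatter. Compound 3 `CC(C)[C@H](NC(=O)COc1cccc2ccccc12)C(=O)N[C@@H](CC(=O)O)C(=O)COc1nc2ccccc2[nH]1` differs from compound 2 by (1H-benzimidazol-2-yl)oxy in place of (5-methyl-1,3,4-thiadiazol-2-yl)sulfanyl on a saturated chain carbon bound to a carbonyl carbon. Among the measured compounds shown here, no measured step covers a change of this kind, and the one step known was small, so no change beyond the scatter is expected a 1.3-fold lower number from compound 2 to compound 3 (0.10 log units; within the scatter). Compound 3 is estimated at 150000 nM, with a range from 40000 nM to 400000 nM.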

Compound 3, half-maximal inhibitory concentration: > 200000 nM
Compound 3: only a limit was reported (the forecaster's own chance of this, stated with the estimate: 45%); middle value at least 1.3-fold (0.12 log units) away from the limit.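

Putting (1H-benzimidazol-2-yl)oxy on the saturated chain carbon bound to a carbonyl carbon gives an at least 1.0-fold higher number from compound 2 to compound 3 (0.02 log units; that floor lies within the scatter) in this assay, so a group with a six-membered aromatic ring added to its five-membered one brings no readable gain. The step from compound 1 to compound 3 cannot be read, as both values are limits. These groups cannot be ranked because the values crowd at one limit: the limit of > 200000 nM in this assay, at which 2 of the 3 values shown sit.

As far as these compounds go, whether a simpler phenoxy group on that carbon would give a clearly lower number stays open. So does the effect of changing the naphthyloxy end of the core.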